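This account rests on a few compounds, and the source may have more. Where it says the series, first, only, none or still open, it means among the compounds named here.

Compound 1 `COc1cc(O)cc(O)c1C(=O)/C=C/c1ccc(C)cc1`: > 50000 nM
Compound 2 `COc1cc(OC)c(OC)cc1/C=C/C(=O)c1c(O)cc(O)cc1OC`: 34200 nM

In a functional assay on A549 cells (Homo sapiens) for inhibition, read by MTT assay, with a stated time of 72 h (on this read-out lower numbers stand for stronger inhibition and higher numbers for weaker inhibition), compound 1 gives > 50000 nM, which is a limit of the assay and not a number. Going by the values given here, compound 2 gives 34200 nM, the only numerical reading so far. Compound 3 `COc1cc(O)cc(O)c1C(=O)/C=C/c1ccc(C(F)(F)F)cc1` has trifluoromethyl in place of methyl on an aromatic carbon, para to a large group: trifluoromethyl in place of methyl on an aromatic carbon. Among the compounds with values here, no measured step covers this change, so in this assay no shift in either direction beyond the scatter is expected. The estimated change is an at least 1.2-fold lower number from compound 1 to compound 3 (0.09 log units; that floor lies within the scatter). Compound 3 is expected at 40000 nM, with an estimated range of 15000 nM to 70000 nM.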

Compound 3, half-maximal inhibitory concentration: 15400 nM
Beside the measured number, compound 3's estimate is 2.6-fold (0.41 log units) above it; measured number inside the range.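

In this assay, going by these compounds alone, this place on the aromatic carbon, para to a large group, responds to substitution for the first time, with trifluoromethyl in place of methyl giving an at least 3.2-fold lower number from compound 1 to compound 3 (0.51 log units; beyond the scatter). Compound 1 gives > 50000 nM, which is a limit of the assay and not a number. The step is therefore a floor and not a measured gap: the limit of > 50000 nM in this assay, at which 1 of the 3 values shown sits.

On these data alone, how a chlorine atom, a nitrile or an amine would read at this place stays open. As far as these compounds go, the true size of the step also stays open.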